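Triazole series on SMMC-7721: pyridin-2-yl in place of 4-bromophenyl

A few compounds are considered here, and "the series" means these few. Any claim that something is new, unique, unknown or untested is made for them only; others in the source may bear on it.

Three members of the series have been tested in a functional assay on SMMC-7721 cells (Homo sapiens) for cytotoxicity, read by MTT assay, with a stated time of 4 days; on this read-out lower numbers stand for stronger inhibition and higher numbers for weaker inhibition. Compound 1 `C=C1C[C@]23C[C@@]1(O)CC[C@H]2c1ccc(O)c(C)c1[C@@H]3Cn1cc(-c2ccc(OC)cc2)nn1` returns only a limit of the assay, > 20000 nM. Compound 2 `C=C1C[C@]23C[C@@]1(O)CC[C@@H]2c1cccc(C)c1[C@@H]3Cn1cc(-c2ccc(F)cc2)nn1` likewise returns a limit, > 20000 nM. Compound 3 `Cc1ccc(S(=O)(=O)Oc2ccc3c(c2C)[C@H](Cn2cc(-c4ccc(Br)cc4)nn2)[C@@]24CC(=O)[C@@](C)(CC[C@@H]32)C4)cc1`, which carries a tosyl-protected phenol and a ketone on the shared core, also returns a limit in this assay, > 20000 nM. Compound 3 therefore stands at the limit of > 20000 nM in this assay, at which 3 of the 3 values shown sit, and no ordering among the three measured compounds can be read from these numbers.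

Compound 4 `Cc1ccc(S(=O)(=O)Oc2ccc3c(c2C)[C@H](Cn2cc(-c4ccccn4)nn2)[C@@]24CC(=O)[C@@](C)(CC[C@@H]32)C4)cc1` is the next member to be measured in this assay. It differs from compound 3 in one place: pyridin-2-yl in place of 4-bromophenyl on an aromatic carbon. The rest of the molecule, including the protected phenol, the ketone and the five-membered aromatic ring with 3 nitrogen, is unchanged.

Among the measured compounds shown here, no step between two measured compounds is available, and the only information is that all three values shown sit at the limit. On that basis the step expected a step that the limit leaves unreadable from compound 3 to compound 4 is none beyond the scatter. For compound 4 the estimate is 30000 nM, with a range from 10000 nM to 100000 nM, and the assay is expected most likely to report only a limit again.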

Compound 4, half-maximal inhibitory concentration: > 20000 nM
Compound 4 gave a limit, no number (the forecaster's own chance of this, stated with the estimate: 85%); the middle value does not contradict the limit.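

Compound 4 returns only a limit in this assay, > 20000 nM. Compound 3 also gave a limit, so no step can be read between compound 3 and compound 4, and both stand at: the limit of > 20000 nM in this assay, at which 4 of the 4 values shown sit.

The compounds shown leave open what pyridin-2-yl in place of 4-bromophenyl does to the read-out, and whether any member of the series gives a number in this assay.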